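The source may report more compounds than this note shows. Statements on the series, on what has been measured and on what is new or still open speak of the compounds shown alone.

Compound 1 `O=c1[nH]nc2n(c1=O)CCN2c1ccccc1` is the point of departure. In a functional assay on T47D cells (Homo sapiens) for cytotoxicity, with a stated time of 72 h, tested at 50 ug/mL (on this read-out higher numbers stand for a stronger effect at the one concentration tested and lower numbers for a weaker effect), compound 1 gives 0%. Two measured relatives differ from it in one place. Compound 2 `COc1ccccc1N1CCn2c1n[nH]c(=O)c2=O` carries methoxy in place of hydrogen on an aromatic carbon, and in this assay compound 2 gives 9%. The step reads a number 9 percentage points higher from compound 1 to compound 2 (within the scatter). Compound 3 `O=c1[nH]nc2n(c1=O)CCN2c1cccc(Cl)c1` carries chloro in place of hydrogen on an aromatic carbon, and compound 3 gives 0%. That step reads no change at the digits printed from compound 1 to compound 3 (within the scatter). Compound 1 is thus level with compound 3 at the digits reported, the two together the lowest of the three numbers, while compound 2 is the furthest away, its number higher but still within the scatter of the measurement.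

Compound 4 `COc1ccc(N2CCn3c2n[nH]c(=O)c3=O)cc1` has not yet been measured. It differs from compound 1 as follows: methoxy in place of hydrogen on an aromatic carbon. Among the compounds with values here, the one measured step that bears on it is the methoxy step already seen, which gave a number 9 percentage points higher from compound 1 to compound 2 (within the scatter), a shift that does not leave the scatter. Within the data shown here, no measured step in this small series goes beyond the scatter, so the expected step for compound 4 in this assay is a number 5 percentage points higher from compound 1 to compound 4 (within the scatter). Compound 4 is therefore estimated at 5%, within a range from 0% to 18%.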

Compound 4, a percentage reported as inhibition, at one concentration (the size of the read-out at that concentration, not a potency): 21%
Compound 4: the middle estimate sits 16 percentage points below what was measured, and the stated range ends below it.
By their numbers in this assay, from the lowest: compounds 1, 3 and 2 (each within the scatter of the next); then compound 4.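

In this assay, within the data shown here, methoxy para to a large group gives a number 21 percentage points higher from compound 1 to compound 4 (beyond the scatter), the first step to go beyond the scatter, though it remains a modest one. The same exchange of hydrogen for methoxy gave a number 9 percentage points higher from compound 1 to compound 2 (within the scatter), and compounds 2 and 4 differ only in where the methoxy sits on the six-membered aromatic ring, so this change does not give a step beyond the scatter at every carbon of that ring. Nothing among the data presented accounts for this difference between the two placements.

The compounds shown leave open whether the step belongs to methoxy itself or would also appear with a hydroxyl, an amine or a longer chain such as ethoxy on the same carbon. They also leave open how compound 4 would behave at other concentrations, as its reading comes from a single concentration and says nothing of potency.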